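From 2-chlorophenyl to 4-ethoxyphenyl on the shared core

A few compounds are considered here, and "the series" means these few. Any claim that something is new, unique, unknown or untested is made for them only; others in the source may bear on it.

Among the measured compounds shown here, in a functional assay on CCRF-CEM cells (Homo sapiens) for antiproliferative activity (on this read-out lower numbers stand for stronger inhibition and higher numbers for weaker inhibition), compound 2 `COc1cc(C(=O)c2sc(-c3ccccc3Cl)cc2N)cc(OC)c1OC` gives 16 nM, the lowest of the three numbers so far. Compound 1 `COc1cc(C(=O)c2sc(-c3ccc(Cl)cc3)cc2N)cc(OC)c1OC` gives 70 nM and compound 3 `COc1cc(C(=O)c2sc(-c3cc(OC)c(OC)c(OC)c3)cc2N)cc(OC)c1OC` gives 840 nM, both higher than compound 2 and beyond the scatter.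

Compound 4 `CCOc1ccc(-c2cc(N)c(C(=O)c3cc(OC)c(OC)c(OC)c3)s2)cc1`, not yet measured, carries 4-ethoxyphenyl in place of 2-chlorophenyl on an aromatic carbon, next to the ring sulfur: 4-ethoxyphenyl in place of 2-chlorophenyl on an aromatic carbon.

For the measured compounds named here, the only measured step at this place is a 4.4-fold lower number from compound 1 to compound 2 (0.64 log units; beyond the scatter), a modest one, with 2-chlorophenyl replacing 4-chlorophenyl. By name, 4-ethoxyphenyl stands closer to the 4-chlorophenyl of compound 1 than to 2-chlorophenyl. A step of similar size is therefore expected in this assay, toward a higher number. Going by the values given here, no measured compound carries an ethoxy group, so this expectation stays loose.

The estimated step is a 3.1-fold higher number from compound 2 to compound 4 (0.49 log units; beyond the scatter). For compound 4 the expected value is 50 nM, with an estimated range of 10 nM to 250 nM.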

Compound 4, half-maximal inhibitory concentration: 270 nM
Compound 4: middle estimate off by 5.4-fold (0.73 log units), on the low side; the whole stated range lies below it.
By their numbers in this assay, from the lowest: compound 2; then compound 1; then compound 4; then compound 3.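

In this assay, among the compounds shown here, the change to 4-ethoxyphenyl gives a 17-fold higher number from compound 2 to compound 4 (1.23 log units; beyond the scatter), a large step, whereas the only earlier step at this position, a 4.4-fold lower number from compound 1 to compound 2 (0.64 log units; beyond the scatter), was modest. The group itself also matters, and not only where it sits on the phenyl ring: ethoxy in place of chloro gives a 3.9-fold higher number from compound 1 to compound 4 (0.59 log units; beyond the scatter), so at this place on the phenyl ring, the chloro of compound 1 gives the lower number. Nothing on hand accounts for either step.

Still open, from the compounds shown here alone, is whether ethoxy, moved to the place that chloro holds in compound 2, would give a lower number than compound 4 does. Going by these compounds, it is also open how a longer propoxy chain or an amine in place of ethoxy would read on the shared core.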